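A Sulfamoyl-for-Carbamoyl Swap in an Inactive Sulfonamide Series

The compounds below may be only part of what the source reports. "The series", "measured", "known", "first", "only" and "open" are said of these compounds alone.

In a functional assay on MIA PaCa-2 cells (Homo sapiens) for inhibition, read by MTT assay, with a stated time of 3 days (on this read-out higher numbers stand for weaker inhibition and lower numbers for stronger inhibition), compound 2 `CCOC(=O)[C@@H]1CCCN(S(=O)(=O)c2ccc(C(=O)N(CC)CC)cc2)C1` gives > 10000 nM, which is a limit of the assay. Compound 1 `CCOC(=O)[C@H]1CCN(S(=O)(=O)c2ccc(S(=O)(=O)N(CC)CC)cc2)C1` likewise reaches only the limit > 10000 nM in this assay. Compound 3 `CCN(CC)S(=O)(=O)c1ccc(S(=O)(=O)N2CCC[C@@H](C(=O)N3CCC(c4nc(C(C)C)no4)CC3)C2)cc1` also stops at the limit > 10000 nM in this assay. All three values shown share (the limit of > 10000 nM in this assay, at which 3 of the 3 values shown sit), so compound 2 stands where every measured compound stands. Compound 4 `CCOC(=O)[C@@H]1CCCN(S(=O)(=O)c2ccc(S(=O)(=O)N(C)C)cc2)C1` has not been measured; it differs from compound 2 by dimethylsulfamoyl in place of diethylcarbamoyl on an aromatic carbon. Going by the values given here, no step between measured compounds is known, and from this change the author expects no step beyond the scatter in this assay. The estimate for compound 4 is 15000 nM in this assay, between 5000 nM and 50000 nM. The expected step that the limit leaves unreadable from compound 2 to compound 4 is within the scatter.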

Compound 4, half-maximal inhibitory concentration: > 10000 nM
Compound 4: a limit, no number; the forecaster's own chance of this, stated with the estimate: 85%; the middle value is on the limit's open side.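

In this assay, going by these compounds alone, compound 2 and compound 4 both stop at a limit, so no step between them can be read. The compounds shown leave open which change, if any, would give a readable number: the limit of > 10000 nM in this assay, at which 4 of the 4 values shown sit.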